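Working notes: one added methoxy on compound 2

The compounds below may be only part of what the source reports. "The series", "measured", "known", "first", "only" and "open" are said of these compounds alone.

compound 1 `COc1cc(/C=C/C(=O)c2cc3cccc(OC)c3oc2=O)cc(OC)c1OC`: 1360 nM
compound 2 `COc1ccc(/C=C(\C#N)C(=O)N/N=C(\C)c2cc3cccc(OC)c3oc2=O)cc1`: 3960 nM

In a functional assay on K562 cells (Homo sapiens) for antiproliferative activity, read by MTT assay, with a stated time of 48 h (on this read-out lower numbers stand for stronger inhibition and higher numbers for weaker inhibition), compound 2 stands highest of the two numbers at 3960 nM, while compound 1 lies lower at 1360 nM. The gap between these two compounds is larger than the usual scatter. Compound 3 `COc1ccc(/C=C(\C#N)C(=O)N/N=C(\C)c2cc3cccc(OC)c3oc2=O)cc1OC` follows from compound 2 by methoxy in place of hydrogen on an aromatic carbon, taking 4-methoxyphenyl to 3,4-dimethoxyphenyl. Among the compounds with values here, no measured step covers this change. In this assay a small move towards a lower number is expected, probably none beyond the scatter: a 1.3-fold lower number from compound 2 to compound 3 (0.12 log units; within the scatter). For compound 3 the estimate is 3000 nM, with a range of 1100 nM to 8000 nM.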

Compound 3, half-maximal inhibitory concentration: 8710 nM
Compound 3: middle estimate off by 2.9-fold (0.46 log units), on the low side; the measured number lies above the stated range.
By their numbers in this assay, from the lowest: compound 1; then compound 2; then compound 3.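

In this assay, methoxy in place of hydrogen on an aromatic carbon, ortho to a methoxy group, gives a 2.2-fold higher number from compound 2 to compound 3 (0.34 log units; beyond the scatter), a modest step towards weaker inhibition that lies beyond the scatter. Within the data shown here, this is the only single-place step, and it shows a loss rather than a gain at this position on going from 4-methoxyphenyl to 3,4-dimethoxyphenyl. Nothing at hand accounts for the loss.

From the compounds shown here alone, whether the loss is specific to methoxy or extends to other groups at this position stays open; a hydroxyl, a fluorine or an amine there would test this. Compound 1 differs from compound 2 in more than one place and cannot settle it.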